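The source may report more compounds than this note shows. Statements on the series, on what has been measured and on what is new or still open speak of the compounds shown alone.

Measured compounds:
Compound 1 `CC[C@H](C)[C@H](N)CN(C(=O)[C@@H]1C[C@H]1c1ccccc1)c1ccc(-c2ccccc2)cc1` — in a functional assay for agonist activity at G protein-coupled receptor 88 (Homo sapiens), read by HTRF and cAMP accumulation (a higher number here means that more compound is needed for the effect, a lower number that less compound is needed), compound 1 gives 230 nM; 800 nM (2 entries).
Compound 2 `N[C@@H](CC1CCCCC1)CN(C(=O)[C@@H]1C[C@H]1c1ccccc1)c1ccc(-c2ccccc2)cc1` — in this assay compound 2 gives 1.7 nM.

Compound 2 stands as the lower of the two numbers shown in this assay, with one further entry that carries no single number. The two entries of compound 1 the several entries of compound 1 in this assay, 230 nM; 800 nM (2 entries) show how far repeat determinations of one compound can lie apart, so any comparison across compounds has to be read with that in mind.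

Compound 3 `O=C([C@@H]1C[C@H]1c1ccccc1)N(CC1CCCNC1)c1ccc(-c2ccccc2)cc1` differs from compound 2 in one place: piperidin-3-yl in place of 1-amino-2-cyclohexylethyl on a saturated chain carbon bound to an amide-type nitrogen. The basic nitrogen is kept, but the cyclohexylmethyl branch is gone and the amine now sits within the ring.

Among the compounds with values here, no measured pair in this set carries exactly this change. Compound 1, which also lacks the cyclohexyl group, sits far above compound 2 in this assay, and that gap is the main guide here. Compound 3 is therefore expected to lose potency, with a step of a 120-fold higher number from compound 2 to compound 3 (2.07 log units; beyond the scatter) that goes well beyond the scatter. For compound 3 the estimate in this assay is 200 nM, with a range from 30 nM to 1500 nM.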

Compound 3, half-maximal effective concentration: 10 nM
Beside the measured number, compound 3's estimate is 20-fold (1.30 log units) above it; the whole stated range lies above it.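

In this assay, swapping 1-amino-2-cyclohexylethyl for piperidin-3-yl on a saturated chain carbon bound to an amide-type nitrogen gives a 5.9-fold higher number from compound 2 to compound 3 (0.77 log units; beyond the scatter), a real but modest cost for replacing the whole group. Within the data shown here, this is the first sign that this position does not need the carbon-only cyclohexyl ring for activity, since compound 3 lacks that ring and still gives 10 nM, provided a nitrogen is kept within the entering group. The exact size of the step should still be read with some caution, since repeat determinations in this assay can lie far apart, as seen in: the several entries of compound 1 in this assay, 230 nM; 800 nM (2 entries)

The single change removes the cyclohexyl ring, moves the amine into a ring and shortens the group all at once, so the compounds shown cannot assign the step to any one of these. They also leave open whether the placement of the ring nitrogen matters, as a piperidin-4-yl group would show, and whether a pyrrolidin-3-yl group or a methyl group on the piperidine nitrogen would be accepted at this position.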